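Methoxy additions across two cores, notes toward compound 4

The source may hold more compounds than are shown below. What is called first, only, known or untested is meant among the compounds shown, and "the series" means these compounds.

Compound 1 `COc1ccc(-c2[nH]c3ccccc3c2/C=C(\C#N)S(=O)(=O)c2ccccc2)cc1` gives 863 nM in a functional assay on SNB-19 cells (Homo sapiens) for inhibition, read by sulforhodamine B assay, with a stated time of 48 h; on this read-out higher numbers stand for weaker inhibition of growth and lower numbers for stronger inhibition of growth. Compound 3 `COc1ccc(-c2[nH]c3ccc(OC)cc3c2/C=C(\C#N)S(=O)(=O)c2ccccc2)cc1` gives 3200 nM in this assay; the step is a 3.7-fold higher number from compound 1 to compound 3 (0.57 log units; beyond the scatter), the change being (methoxy in place of hydrogen on an aromatic carbon). Compound 2 `COc1ccc2[nH]c(-c3ccccc3)c(C=C(C#N)C#N)c2c1` gives 6000 nM in this assay; the difference between the cores of compound 1 and compound 2 is not broken down here. The values of compound 2 and compound 3 lie within the scatter of each other, while compound 1 shows a lower number than compound 2, beyond the scatter. Compound 4 `COc1ccc(-c2[nH]c3ccc(OC)cc3c2C=C(C#N)C#N)cc1` is not yet measured; it differs from compound 2 by methoxy in place of hydrogen on an aromatic carbon. Here the place is para to a large group on a ring of carbon only, whereas in compound 3 the ring is part of a fused system, meta and para to a fused ring, so this is the same kind of change, not the same. The expected step of a 1.5-fold higher number from compound 2 to compound 4 (0.18 log units; within the scatter) rests on a 3.7-fold higher number from compound 1 to compound 3 (0.57 log units; beyond the scatter), softened for the different place. Compound 4 is expected to give 9000 nM, estimated between 3500 nM and 25000 nM.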

Compound 4, concentration for 50% growth inhibition: 13700 nM
Estimate against measurement, compound 4: 1.5-fold (0.18 log units) below; low and high end bracket the measured number.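

In this assay the methoxy change gives a higher number on both cores, the new step being a 2.3-fold higher number from compound 2 to compound 4 (0.36 log units; beyond the scatter). Set side by side, the two steps do not differ beyond the scatter: the same change on two cores in this assay, a 3.7-fold higher number (0.57 log units; beyond the scatter) from compound 1 to compound 3 and a 2.3-fold higher number (0.36 log units; beyond the scatter) from compound 2 to compound 4, 1.6-fold (0.21 log units) apart, within the scatter of two such steps. The change therefore carries in the same direction and to a comparable size across these two pairs, but the methoxy enters at a different place in each, and two pairs cannot show that the step holds on other cores or at other places.

Still open, as far as these compounds go, is whether the step is specific to methoxy or would also appear with an amine, a hydroxyl or a longer alkoxy chain at these places. Also open, from the compounds shown here alone, is how any such group would behave on a third core.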